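This account rests on a few compounds, and the source may have more. Where it says the series, first, only, none or still open, it means among the compounds named here.

Measured compounds in an ADME assay on MT4 cells (Homo sapiens) for cytotoxicity, read by MTT assay, with a stated time of 4 days; a lower number here means that less compound is tolerated, a higher number that more compound is tolerated:
- compound 1 `Cc1cc(-c2cc(F)cc(F)c2)cc(C)c1Nc1ccnc(Nc2ccc(C#N)cc2)n1`: 3910 nM
- compound 2 `Cc1cc(-c2cccc(Cl)c2)cc(C)c1Nc1ccnc(Nc2ccc(C#N)cc2)n1`: 2160 nM
- compound 3 `Cc1cc(-c2ccccc2Cl)cc(C)c1Nc1ccnc(Nc2ccc(C#N)cc2)n1`: 3990 nM

Compound 1 stands second highest of the three numbers in this assay; its nearest neighbour is compound 3 and its furthest is compound 2, and both gaps are within the scatter. Among the compounds with values here, the three compounds differ only in the aryl group on the shared core; the steps of a 1.8-fold lower number from compound 1 to compound 2 (0.26 log units; within the scatter) and a 1.0-fold higher number from compound 1 to compound 3 (0.01 log units; within the scatter) and a 1.8-fold higher number from compound 2 to compound 3 (0.27 log units; within the scatter) are all within the scatter, so on the numbers so far the pendant aryl substitution pattern has not moved the read-out.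

Compound 4 `COc1cccc(-c2cc(C)c(Nc3ccnc(Nc4ccc(C#N)cc4)n3)c(C)c2)c1` is not yet measured. Relative to compound 1 the change is 3-methoxyphenyl in place of 3,5-difluorophenyl on an aromatic carbon. Within the data shown here, the steps that bear on it are the same kind of aryl exchange as from compound 1 to compound 2 and from compound 1 to compound 3, and neither moved the number beyond the scatter. No step beyond the scatter is therefore expected in this assay.

For compound 4 the estimated value in this assay is 3500 nM, with a range of 1700 nM to 7500 nM. This estimate means a step of a 1.1-fold lower number from compound 1 to compound 4 (0.05 log units; within the scatter) from compound 1, which is expected to sit within the scatter.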

Compound 4, half-maximal cytotoxic concentration: 2990 nM
Compound 4: middle estimate off by 1.2-fold (0.07 log units), on the high side; the range from low to high includes it.
By their numbers in this assay, from the lowest: compounds 2, 4, 1 and 3 (each within the scatter of the next).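

In this assay, exchanging 3,5-difluorophenyl for 3-methoxyphenyl puts an oxygen and a hydrogen-bond acceptor on the aryl group at this position, yet the step stays within the scatter (a 1.3-fold lower number from compound 1 to compound 4 (0.12 log units; within the scatter)), as does the exchange of 2-chlorophenyl for 3-methoxyphenyl (a 1.3-fold lower number from compound 3 to compound 4 (0.13 log units; within the scatter)). The direct exchange of chloro for methoxy also stays within the scatter (a 1.4-fold higher number from compound 2 to compound 4 (0.14 log units; within the scatter)), so across these four compounds the read-out does not separate methoxy from the halogen-bearing aryl groups. No measurement shown bears on why these steps are small, and no cause can be assigned.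

Still open, on these data alone, is whether an amine or a carboxylic acid on this aryl group would give a step beyond the scatter. As far as these compounds go, a longer alkoxy chain in place of methoxy also remains open.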